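This account rests on a few compounds, and the source may have more. Where it says the series, first, only, none or still open, it means among the compounds named here.

Within the data shown here, in a functional assay on OVCAR-5 cells (Homo sapiens) for inhibition, with a stated time of 48 h, tested at 30 uM (on this read-out lower numbers stand for less inhibition of growth and higher numbers for more inhibition of growth at the one concentration tested), compound 1 (`C=C[C@@](C)(/C=C/c1ccc(OC(C)=O)cc1)CCC=C(C)C`) gives 62%, the higher of the two numbers so far. Among the measured compounds shown here, the only other measured compound, compound 2 (`C=C[C@@](C)(/C=C/c1ccc(OC(=O)CCCCCCCCC)cc1)CCC=C(C)C`), gives 29%. This is a number 33 percentage points lower from compound 1 to compound 2 (beyond the scatter), with octyl in place of hydrogen on a saturated chain carbon bound to a carbonyl carbon. Compound 3 (`C=C[C@@](C)(/C=C/c1ccc(OC)cc1)CCC=C(C)C`) is still unmeasured and differs from compound 1 in another way: methyl in place of acetyl on an oxygen on an aromatic ring. For the measured compounds named here, the change is acetoxy to methoxy, and no measured step tests it. The step to compound 2 lengthens the chain instead, so it bears only indirectly, showing that a change at this oxygen-bound group can move the number widely: a number 33 percentage points lower from compound 1 to compound 2 (beyond the scatter). The methyl that enters is small, so only a slight fall, within the scatter, is expected: a number 7 percentage points lower from compound 1 to compound 3 (within the scatter). For compound 3 the estimated value is 55%, within an expected range of 35% to 72%.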

Compound 3, percent growth inhibition at one concentration: 29%
Estimate against measurement, compound 3: 26 percentage points above; measured number below the stated range.
By their numbers in this assay, from the lowest: compounds 2 and 3 (each within the scatter of the next); then compound 1.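

In this assay the exchange of methyl in place of acetyl on an oxygen on an aromatic ring is now read directly as a number 33 percentage points lower from compound 1 to compound 3 (beyond the scatter) and shows that even this small change at the oxygen carries a large step. The number does not follow the size of the group on this oxygen in these compounds: compound 2, with its longer ester chain, gives 29% and compound 3, with the small methyl, gives 29% and these two values lie within the scatter of each other, leaving only the acetoxy compound 1 apart. Nothing available here explains why the acetoxy compound stands apart.

Still open, as far as these compounds go, is how a free hydroxyl on this oxygen would compare with acetoxy and methoxy. Also open, from the compounds shown here alone, is where a propanoyl or butanoyl ester would fall, as chains of intermediate length between the acetyl of compound 1 and the long ester chain of compound 2.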